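The source may report more compounds than this note shows. Statements on the series, on what has been measured and on what is new or still open speak of the compounds shown alone.

Of the compounds shown here, two have been measured in a functional assay on HeLa cells (Homo sapiens) for inhibition, read by sulforhodamine B assay, with a stated time of 48 h; a lower number here means a stronger inhibitor of growth, a higher number a weaker inhibitor of growth. Compound 1 `O=C(/C=C/c1c(Cl)nc2ccccn12)N1CCC=CS1(=O)=O` gives 8200 nM. Compound 2 `O=C(/C=C/c1ccoc1)N1CCC=CS1(=O)=O` gives 20300 nM, the higher of the two numbers, and its gap to compound 1 lies beyond the usual scatter. Compound 3 `O=C(/C=C/c1cccs1)N1CCC=CS1(=O)=O` differs from compound 2 in one place: thiophen-2-yl in place of furan-3-yl on a double-bonded chain carbon bound to a double-bonded chain carbon. Going by the values given here, no measured pair shows this change, so its size cannot be read from the data; one five-membered aromatic ring with one hetero atom is exchanged for another. The expected step is a 1.4-fold lower number from compound 2 to compound 3 (0.13 log units; within the scatter), no more than the scatter. Compound 3 is estimated at 15000 nM, within 5000 nM to 45000 nM.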

Compound 3, concentration for 50% growth inhibition: 18800 nM
For compound 3 the middle estimate is 1.3-fold (0.10 log units) below the measured one; the measured number falls inside the stated range.
By their numbers in this assay, from the lowest: compound 1; then compounds 3 and 2 (each within the scatter of the next).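

In this assay, going by these compounds alone, thiophen-2-yl in place of furan-3-yl on a double-bonded chain carbon bound to a double-bonded chain carbon gives a 1.1-fold lower number from compound 2 to compound 3 (0.03 log units; within the scatter), the first step that can be read at this position. This exchange of one five-membered aromatic ring with one hetero atom for another therefore does not separate the two compounds. Nothing measured here accounts for this result. The compounds shown leave open whether a phenyl ring at this place, or an amine or a carboxylic acid on the thiophen-2-yl ring, would move the number beyond the scatter.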